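This account rests on a few compounds, and the source may have more. Where it says the series, first, only, none or still open, it means among the compounds named here.

Compound 1 `Cc1cc(NC(=O)c2ccc(Cl)c([N+](=O)[O-])c2)ccc1NS(C)(=O)=O` gives 108000 nM in an ADME assay on RAW264.7 cells (Mus musculus) for cytotoxicity, read by MTT assay, with a stated time of 48 h; on this read-out lower numbers stand for stronger inhibition and higher numbers for weaker inhibition. Within the data shown here, compound 2 `CS(=O)(=O)Nc1ccc(NC(=O)c2ccc(Cl)c([N+](=O)[O-])c2)cc1F` gives 102000 nM in this assay; the step of a 1.1-fold lower number from compound 1 to compound 2 (0.02 log units; within the scatter) leaves compound 2 within the scatter of compound 1, the only other number. Compound 3 `O=C(Nc1ccc(NS(=O)(=O)C(F)(F)F)c(F)c1)c1ccc(Cl)c([N+](=O)[O-])c1` differs from compound 2 by trifluoromethyl in place of methyl on a sulfonyl sulfur. Among the measured compounds shown here, no measured step covers this change; the single step from compound 1 to compound 2 concerns a different position and stayed within the scatter. Nothing in the series supports a shift beyond the scatter in this assay, so compound 3 is expected to sit close by, at 100000 nM with a range of 40000 nM to 250000 nM, an expected step of a 1.0-fold lower number from compound 2 to compound 3 (0.01 log units; within the scatter).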

Compound 3, half-maximal inhibitory concentration: 188000 nM
Estimate against measurement, compound 3: 1.9-fold (0.27 log units) below; the measured number falls inside the stated range.
By their numbers in this assay, from the lowest: compounds 2, 1 and 3 (each within the scatter of the next).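

The sulfonyl sulfur, a position the earlier step did not touch, now has a reading of its own: trifluoromethyl in place of methyl there gives a 1.8-fold higher number from compound 2 to compound 3 (0.27 log units; within the scatter) in this assay. This exchange on the sulfur therefore stays inside the scatter of the read-out. No available data bear on the reason for this result. Going by these compounds, it remains open whether another group on the sulfonyl sulfur, such as an amine or a longer alkyl chain, would give a step beyond the scatter.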